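A few compounds are considered here, and "the series" means these few. Any claim that something is new, unique, unknown or untested is made for them only; others in the source may bear on it.

Measured in a functional assay on the whole organism (Myocardium) with Canis familiaris (Canis lupus familiaris) as the target, at a dose of 8.75 mg/kg by the intravenous route; on this read-out higher numbers stand for an effect only at larger amounts of compound and lower numbers for an effect already at smaller amounts:
- compound 1 `COc1ccc(OC)c2c(C)nc(O)nc12`: 8.75 mg/kg
- compound 2 `CCc1nc(O)nc2cc(OC)c(OC)cc12`: 3.4 mg/kg

Of these two numbers, compound 2 holds the lower at 3.4 mg/kg, and the gap to compound 1 lies beyond the scatter. Compound 3 `COc1cc2nc(O)nc(C(F)(F)F)c2cc1OC` has not yet been measured. It carries trifluoromethyl in place of ethyl on an aromatic carbon, next to the ring nitrogen (trifluoromethyl in place of ethyl on an aromatic carbon). Going by the values given here, no measured pair differs in one place only, so this expectation has no direct support. A modest move towards a higher number in this assay is expected, with no change beyond the scatter also possible. The expected step is a 1.5-fold higher number from compound 2 to compound 3 (0.17 log units; within the scatter). For compound 3 the estimate is 5 mg/kg, with an expected range of 1.5 mg/kg to 15 mg/kg.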

Compound 3, dose for half-maximal effect: > 8.75 mg/kg
Compound 3 ended at the assay's limit; the forecaster's own chance of this, stated with the estimate: 5%; at least 1.7-fold (0.24 log units) between middle value and limit.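

In this assay, going by these compounds alone, trifluoromethyl in place of ethyl on an aromatic carbon, next to the ring nitrogen, gives an at least 2.5-fold higher number from compound 2 to compound 3 (0.41 log units; beyond the scatter) as the first comparison that differs in one place, so the read-out does respond to the group at this position. For compound 3 the entry > 8.75 mg/kg is a limit of the assay and not a number, so the step has a lower bound but no known size: the limit of > 8.75 mg/kg in this assay, at which 1 of the 3 values shown sits.

As far as these compounds go, how an amine or a propyl chain at this position would read stays open. From the compounds shown here alone, whether the step carries over to the core of compound 1 also stays open.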